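Aryl Swap on the Shared Core in Cell Inhibition

The compounds below may be only part of what the source reports. "The series", "measured", "known", "first", "only" and "open" are said of these compounds alone.

compound 1 `Cc1ccc(Nc2cc(NC(=O)Nc3c(Cl)cccc3Cl)ncn2)cc1F`: 92%
compound 2 `Cc1cc(F)cc(Nc2cc(NC(=O)Nc3c(Cl)cccc3Cl)ncn2)c1`: 80%

In a functional assay on PC-9 cells (Homo sapiens) for inhibition, read by MTT assay, with a stated time of 48 h, tested at 10 uM (on this read-out higher numbers stand for more inhibition at the one concentration tested (going by the name of the read-out) and lower numbers for less inhibition), compound 1 gives 92% and compound 2 gives 80%. Among the measured compounds shown here, compound 2 stands lowest of these two numbers; the single measured step, a number 12 percentage points lower from compound 1 to compound 2 (beyond the scatter), is modest but beyond the scatter, and it shows that exchanging the aryl group on the nitrogen of the shared core can shift the read-out by a modest amount.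

Compound 3 `COc1ccc(Br)cc1Nc1cc(NC(=O)Nc2c(Cl)cccc2Cl)ncn1` is not yet measured. Its change from compound 2 is 5-bromo-2-methoxyphenyl in place of 3-fluoro-5-methylphenyl on a nitrogen on an aromatic ring. For the measured compounds named here, no measured step involves the 5-bromo-2-methoxyphenyl group, so the one step available only sets a scale. The step of a number 10 percentage points lower from compound 2 to compound 3 (within the scatter) is therefore expected to be modest, with a somewhat lower number thought more likely than a higher one. Compound 3 is estimated to give 70%, in a range from 40% to 95%.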

Compound 3, a percentage reported as inhibition, at one concentration (the size of the read-out at that concentration, not a potency): 69%
Compound 3: middle estimate off by 1 percentage points, on the high side; the measured number falls inside the stated range.
By their numbers in this assay, from the lowest: compound 3; then compound 2; then compound 1.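

The earlier pair only exchanged one fluoro-methylphenyl group for another, whereas the 5-bromo-2-methoxyphenyl group brings a different set of substituents to the same place, on a nitrogen on an aromatic ring. In this assay this change gives a number 11 percentage points lower from compound 2 to compound 3 (beyond the scatter) and a number 23 percentage points lower from compound 1 to compound 3 (beyond the scatter), so all three aryl groups leave a measurable read-out, while compound 3 , at 69%, sits lowest of the three by steps beyond the scatter. No evidence is available to explain why the read-out falls with this group.

The bromo and methoxy groups enter together, so the compounds shown do not separate what each contributes to the step. They also leave open how this position would respond to an aryl group carrying an amine or a carboxylic acid.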